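Thione methylation in a diaryl ether triazole series

The source may hold more compounds than are shown below. What is called first, only, known or untested is meant among the compounds shown, and "the series" means these compounds.

Compound 1 `S=c1[nH]nc(Cc2ccccc2Oc2ccccc2)[nH]1` and compound 2 `S=c1[nH]nc(Cc2ccc(Cl)cc2Oc2ccccc2Cl)[nH]1` share the same core and differ only in the substitution of the aromatic rings. In a functional assay on the whole organism (strain NMRI) with Mus musculus as the target, with a stated time of 60 min, at a dose of 20 mg/kg by the intraperitoneal route (a lower number here means a weaker effect, a higher number a stronger effect of the compound at the dose given), compound 1 gives 160%. In this assay compound 2 gives 159%; the two numbers lie within the scatter of each other, so no order between compound 1 and compound 2 can be read from them, and both sit at the same level.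

Compound 3 `CSc1nnc(Cc2ccc(Cl)cc2Oc2ccccc2Cl)[nH]1` differs from compound 2 by a group of 7 heavy atoms (3 carbon, 3 nitrogen, 1 sulfur; one five-membered aromatic ring with 3 hetero atoms) in place of a group of 6 heavy atoms (2 carbon, 3 nitrogen, 1 sulfur; one five-membered aromatic ring with 3 hetero atoms), on a saturated chain carbon bound to an aromatic carbon. Going by the values given here, no measured pair shows what this kind of change does, so the expectation rests on the level of compound 2 alone. The step from compound 2 to compound 3 is estimated as a number 14 percentage points lower from compound 2 to compound 3 (beyond the scatter), a change expected to be small, most likely downward, and possibly not beyond the scatter. For compound 3 the expected read-out in this assay is 145%, with a range from 110% to 175%.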

Compound 3, a percentage reported as activity, at one dose (the size of the read-out at that dose, not a potency): 170%
Beside the measured number, compound 3's estimate is 25 percentage points below it; measured number inside the range.
By their numbers in this assay, from the lowest: compounds 2, 1 and 3 (each within the scatter of the next, the first and the last beyond it).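

Methylating the thione of compound 2 in this assay gives a number 11 percentage points higher from compound 2 to compound 3 (beyond the scatter), the first measured change on a saturated chain carbon bound to an aromatic carbon in this series. The step is modest, but it shows that the effect at the dose given does not depend on keeping the thione form in this chlorinated compound. The change also takes the group from 2 hydrogen-bond donors, 2 hydrogen-bond acceptors to 1 hydrogen-bond donor, 3 hydrogen-bond acceptors, but no measurement ties this count to the read-out or otherwise accounts for the step.

Still open, going by these compounds, is whether the same methylation on the core of compound 1 gives a step of like size. It is also open whether an ethyl group or an amine in place of the methyl group holds the read-out at this level, and a single dose gives no potency for any of these compounds.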